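Benzyloxy in place of (piperidin-1-yl)carbonyl on the shared core

This account rests on a few compounds, and the source may have more. Where it says the series, first, only, none or still open, it means among the compounds named here.

Compound 1 (`COc1ccc(C(=O)/C=C/c2ccc(C(=O)O)cc2)c(O)c1`) carries hydroxy on a carbonyl carbon, and compound 2 (`COc1ccc(C(=O)/C=C/c2ccc(C(=O)N3CCCCC3)cc2)c(O)c1`) carries piperidin-1-yl there. In an ADME assay on SH-SY5Y cells (Homo sapiens) for cytotoxicity, read by MTT assay, with a stated time of 48 h (a higher number here means a weaker inhibitor, a lower number a stronger inhibitor), compound 1 gives > 100000 nM, which is a limit of the assay. In this assay compound 2 gives > 100000 nM, which is also a limit, so compound 2 has no numerical value to stand on. Going by the values given here, the only measured step is a step that the two limits leave unreadable from compound 1 to compound 2, and it offers no size to carry forward. The whole evidence so far is the limit of > 100000 nM in this assay, at which 2 of the 2 values shown sit.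

Compound 3 (`COc1ccc(C(=O)/C=C/c2ccc(OCc3ccccc3)cc2)c(O)c1`) has not been measured in this assay. It differs from compound 2 as follows: benzyloxy in place of (piperidin-1-yl)carbonyl on an aromatic carbon. The change sits para to a large group, on an aromatic carbon. Among the compounds with values here, no measured step covers this exchange, so the data give neither a size nor a direction, and the expectation rests only on compound 2 with its limit of > 100000 nM. The expected change is small, stated as an at least 1.2-fold lower number from compound 2 to compound 3 (0.09 log units; that floor lies within the scatter). A report of only a limit is also quite possible. For compound 3 the estimated value is 80000 nM, with an expected range of 20000 nM to 150000 nM.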

Compound 3, half-maximal inhibitory concentration: > 100000 nM
Compound 3 ended at the assay's limit; the forecaster's own chance of this, stated with the estimate: 60%; middle value at least 1.2-fold (0.09 log units) away from the limit.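

In this assay compound 3 gives > 100000 nM, which is a limit of the assay. The steps among compound 1, compound 2 and compound 3 therefore cannot be read. The compounds shown leave open whether any change on the shared core gives a numerical value, and the record so far is only this: the limit of > 100000 nM in this assay, at which 3 of the 3 values shown sit.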